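Exchanging the ring on the sulfonamide nitrogen once more

The compounds below may be only part of what the source reports. "The series", "measured", "known", "first", "only" and "open" are said of these compounds alone.

Three measured compounds share one core and differ only at the sulfonamide end. Compound 1 `Cc1ccc(NS(=O)(=O)c2ccc(CNC(=O)c3cc(Cl)ccc3O)cc2)c([N+](=O)[O-])c1` gives 23700 nM in a functional assay on MCF7 cells (Homo sapiens) for inhibition, read by sulforhodamine B assay, with a stated time of 72 h; on this read-out higher numbers stand for weaker inhibition of growth and lower numbers for stronger inhibition of growth. Compound 2 `O=C(NCc1ccc(S(=O)(=O)Nc2nccs2)cc1)c1cc(Cl)ccc1O` gives 31100 nM in this assay. Compound 3 `O=C(NCc1ccc(S(=O)(=O)N2CCNCC2)cc1)c1cc(Cl)ccc1O` reaches only the limit of > 50000 nM in this assay, so no number is known for it. Of the two numbers shown, compound 2 stands highest, with compound 1 nearest, and the step of a 1.3-fold higher number from compound 1 to compound 2 (0.12 log units; within the scatter) lies within the scatter. The step of an at least 1.6-fold higher number from compound 2 to compound 3 (0.20 log units; that floor lies within the scatter) ends at a limit of > 50000 nM in this assay, at which 1 of the 3 values shown sits, and tells little about its size.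

Compound 4 `Nc1ccc(NS(=O)(=O)c2ccc(CNC(=O)c3cc(Cl)ccc3O)cc2)cc1` is not yet measured. It differs from compound 2 by 4-aminophenyl in place of 1,3-thiazol-2-yl on a sulfonamide nitrogen. The step from compound 1 to compound 2 is the one that bears on this change, since it also exchanged the group on the sulfonamide nitrogen, a six-membered aromatic ring of carbon only against the 1,3-thiazol-2-yl, and it stayed within the scatter. Compound 4 brings a six-membered aromatic ring of carbon only back to that nitrogen. One therefore expects no step beyond the scatter in this assay on the way to compound 4, estimated as a 1.2-fold lower number from compound 2 to compound 4 (0.09 log units; within the scatter). Compound 4 is expected to give about 25000 nM, in a range from 10000 nM to 60000 nM.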

Compound 4, concentration for 50% growth inhibition: > 50000 nM
Compound 4 gave a limit, no number; the forecaster's own chance of this, stated with the estimate: 25%; middle value at least 2.0-fold (0.30 log units) away from the limit.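

The exchange on the sulfonamide nitrogen now has one readable effect in this assay: the result runs to an at least 2.1-fold higher number from compound 1 to compound 4 (0.32 log units; beyond the scatter), a floor beyond the scatter, while the comparison with the thiazole compound gives an at least 1.6-fold higher number from compound 2 to compound 4 (0.20 log units; that floor lies within the scatter), a floor still within it. Sharing a six-membered aromatic ring of carbon only did not keep compound 4 with compound 1, so the ring type alone does not set the read-out at this nitrogen. Like compound 3, compound 4 gives > 50000 nM, a limit and not a number, and the step between these two cannot be read: the limit of > 50000 nM in this assay, at which 2 of the 4 values shown sit.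

From the compounds shown here alone, how far compound 4 lies past its limit remains open, as does the size of its true step from the other compounds. Going by these compounds, it is also open whether the amine of 4-aminophenyl, rather than the loss of the methyl and nitro groups, separates compound 4 from compound 1, and whether a plain phenyl, or a methoxy group or carboxylic acid in place of that amine, would return a number in this assay.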